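Replacing 4-methoxyphenyl with 3-fluorophenyl in compound 4

The source may report more compounds than this note shows. Statements on the series, on what has been measured and on what is new or still open speak of the compounds shown alone.

Measured in a functional assay on HL-60 cells (Homo sapiens) for cytotoxicity, read by MTT assay, with a stated time of 48 h; a higher number here means a weaker inhibitor, a lower number a stronger inhibitor:
compound 1 `Fc1cccc(-c2nc(Nc3ccccc3)c3ccccc3n2)c1` gives > 50000 nM, a limit of the assay.
compound 2 `Fc1ccc2nc(-c3ccccc3)nc(Nc3ccccc3)c2c1` gives > 50000 nM, a limit of the assay.
compound 3 `COc1ccc(Nc2nc(-c3cccc(F)c3)nc3ccc(F)cc23)cc1` gives 38600 nM.

In this assay, within the data shown here, compound 3 carries the only true number, and the other two values are limits. The top of the scale is set by the limit of > 50000 nM in this assay, at which 2 of the 3 values shown sit.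

Compound 4 `Fc1cccc(Nc2nc(-c3cccc(F)c3)nc3ccc(F)cc23)c1` has not yet been measured. It differs from compound 3 in one place: 3-fluorophenyl in place of 4-methoxyphenyl on a nitrogen on an aromatic ring. In words, 3-fluorophenyl stands in place of 4-methoxyphenyl on a nitrogen on an aromatic ring.

Among the measured compounds shown here, no measured pair isolates this change, so compound 3 at 38600 nM is the only numerical anchor. No step beyond the usual scatter is therefore expected in this assay, although any shift would more likely be towards weaker inhibition. The expected change is a 1.1-fold higher number from compound 3 to compound 4 (0.04 log units; within the scatter). A report of only the assay limit would not be surprising. For compound 4 the estimate is 42000 nM, with an expected range from 20000 nM to 75000 nM.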

Compound 4, half-maximal inhibitory concentration: 43100 nM
The estimate for compound 4 lay 1.0-fold (0.01 log units) below the measured number; the measured number falls inside the stated range.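

In this assay, among these compounds, the first pair that isolates this position gives a 1.1-fold higher number from compound 3 to compound 4 (0.05 log units; within the scatter), so 4-methoxyphenyl and 3-fluorophenyl on this nitrogen cannot be told apart. The hydrogen-bond acceptor counted in 4-methoxyphenyl is absent from 3-fluorophenyl, and this exchange still produces no step beyond the scatter. Compound 3 and compound 4 both carry true numbers, and both remain in the upper part of the scale, which is set by a limit: the limit of > 50000 nM in this assay, at which 2 of the 4 values shown sit.

The compounds shown leave open whether any group on this nitrogen can bring a step beyond the scatter, since only two aryl groups can be compared here. A carboxylic acid or a dimethylamino group on that ring, for example, remains untested in what is shown.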